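Moving the triazole's point of attachment on a saturated ring

This account rests on a few compounds, and the source may have more. Where it says the series, first, only, none or still open, it means among the compounds named here.

In an ADME assay on S9 fraction from liver (Homo sapiens) for metabolic stability, with a stated time of 1 h (a higher number here means that more of the compound is left, a lower number that less of the compound is left), compound 1 `N#Cc1cnc(NCc2cnccc2C(F)(F)F)cc1N[C@H]1CC[C@@H](C(N)=O)CC1` gives 90%. Among the compounds with values here, compound 2 `N#Cc1cnc(NCc2cnccc2C(F)(F)F)cc1N[C@H]1CC[C@@H](c2nc[nH]n2)CC1` gives 13%, the lower of the two numbers so far. Compound 3 `N#Cc1cnc(NCc2cnccc2C(F)(F)F)cc1N[C@H]1CC[C@@H](n2cncn2)CC1` has the same atoms as compound 2, joined differently: 1H-1,2,4-triazol-1-yl in place of 1H-1,2,4-triazol-3-yl on a saturated ring carbon, with 1H-1,2,4-triazol-1-yl in place of 1H-1,2,4-triazol-3-yl on a saturated ring carbon. Within the data shown here, no measured step makes this exact swap. The nearest is the large step of a number 77 percentage points lower from compound 1 to compound 2 (beyond the scatter), where 1H-1,2,4-triazol-3-yl replaced carbamoyl at this same place. That single step shows that this assay can respond strongly to the group here, and compound 2 at 13% leaves far more room upward than downward. A rise beyond the scatter is therefore expected, though its size is uncertain. The estimated change is a number 32 percentage points higher from compound 2 to compound 3 (beyond the scatter). Compound 3 is expected at 45%, within an estimated range of 18% to 80%.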

Compound 3, percent of the compound remaining: 64%
The estimate for compound 3 lay 19 percentage points below the measured number; low and high end bracket the measured number.
By their numbers in this assay, from the lowest: compound 2; then compound 3; then compound 1.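

Compound 2 and compound 3 carry the same triazole atoms on the same saturated ring carbon, so in this assay the change of attachment point alone gives a number 51 percentage points higher from compound 2 to compound 3 (beyond the scatter), a large effect at this position. The triazole attached through its ring nitrogen still does not match the carbamoyl group, with a number 26 percentage points lower from compound 1 to compound 3 (beyond the scatter), so the swap recovers much of the stability but not all of it. Nothing measured here explains why the point of attachment matters so much.

The swap also removes the hydrogen-bond donor counted on the triazole, and these compounds cannot show whether that count is what matters. Going by these compounds, it also remains open where other groups on this ring carbon, such as a carboxylic acid or an amine, would fall in this assay.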